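The source may hold more compounds than are shown below. What is called first, only, known or untested is meant among the compounds shown, and "the series" means these compounds.

Measured compounds and their values in a functional assay on cells for agonist activity at C-X-C chemokine receptor type 4 (Homo sapiens), read by fluorescence and calcium flux, with a stated time of 90 s; a higher number here means that more compound is needed for the effect, a lower number that less compound is needed:

- compound 1 `c1ccc2c(c1)CN[C@@H](CN(CCCCNC1CCCCC1)[C@H]1CCCc3cccnc31)C2` — compound 1 gives > 30000 nM, a limit of the assay.
- compound 2 `C(=C/CN(C[C@H]1Cc2ccccc2CN1)[C@H]1CCCc2cccnc21)\CNCC1CCOCC1` — compound 2 gives > 30000 nM, a limit of the assay.
- compound 3 `C(=C/CN(C[C@H]1Cc2ccccc2CN1)[C@H]1CCCc2cccnc21)\CNC1CCOCC1` — compound 3 gives > 30000 nM, a limit of the assay.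

Among the measured compounds shown here, compound 1 stands at a limit in this assay and not at a number; the two further values shown are limits as well, so no compound in the set can be placed against another, as summarised by the limit of > 30000 nM in this assay, at which 3 of the 3 values shown sit.

Compound 4 `CC(C)(CCN(C[C@H]1Cc2ccccc2CN1)[C@H]1CCCc2cccnc21)CNCC1CCOCC1` is the next compound for this assay. Against compound 1 the change is a group of 12 heavy atoms (10 carbon, 1 nitrogen, 1 oxygen; one six-membered non-aromatic ring with 1 hetero atom) in place of a group of 9 heavy atoms (8 carbon, 1 nitrogen; one six-membered non-aromatic ring of carbon only), on a saturated chain carbon, two bonds along the chain from an amine nitrogen.

Of the measured steps, a step that the two limits leave unreadable from compound 1 to compound 2 and a step that the two limits leave unreadable from compound 1 to compound 3 start from compound 1 and exchange the same part of the molecule, and a step that the two limits leave unreadable from compound 2 to compound 3 connects the two products; none of them can be read, since every value involved is a limit. The change from compound 1 to compound 4 is of the same kind as those steps, and nothing in the set shows a number emerging from them. The expectation for compound 4 is therefore a further limit rather than a readable step, so the step from compound 1 to compound 4 is estimated as a step that the limit leaves unreadable from compound 1 to compound 4. Compound 4 is estimated at 60000 nM, with a range from 15000 nM to 300000 nM.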

Compound 4, half-maximal effective concentration: > 30000 nM
Compound 4 gave a limit, no number (the forecaster's own chance of this, stated with the estimate: 80%); the middle value lies beyond the limit too.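

Compound 4 gives > 30000 nM in this assay, a limit of the assay and not a number, so the step from compound 1 to compound 4 cannot be read. The compounds shown leave open which change, if any, would give a readable value, and how they rank against one another, with every value at one limit: the limit of > 30000 nM in this assay, at which 4 of the 4 values shown sit.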